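This account rests on a few compounds, and the source may have more. Where it says the series, first, only, none or still open, it means among the compounds named here.

Working notes on the series. Compound 1 `O=C(NCC1CCCCC1)c1cccc(/C=C2\CC(=O)N(c3ccccc3)C2=O)c1` carries a cyclohexylmethyl on the amide-type nitrogen. In an ADME assay on HCT-116 cells (Homo sapiens) for cytotoxicity, read by MTT assay, with a stated time of 72 h (on this read-out lower numbers stand for stronger inhibition and higher numbers for weaker inhibition), compound 1 reaches only a limit of the assay, > 100000 nM. Compound 2 `Cc1ccc(NC(=O)c2cccc(/C=C3\CC(=O)N(c4ccccc4)C3=O)c2)cc1` has 4-methylphenyl in place of cyclohexylmethyl on that amide-type nitrogen. In this assay compound 2 also sits at a limit rather than a number, > 100000 nM. The step that the two limits leave unreadable from compound 1 to compound 2 cannot be read because of the limit of > 100000 nM in this assay, at which 2 of the 2 values shown sit. So on the numbers shown compound 2 stands at a limit, and no compound of the set so far gives a number.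

Compound 3 `O=C(Nc1ccc(Cl)cc1)c1cccc(/C=C2\CC(=O)N(c3ccccc3)C2=O)c1` differs from compound 2 by chloro in place of methyl on an aromatic carbon. Among the compounds with values here, no measured step bears on this change, and the only step known, a step that the two limits leave unreadable from compound 1 to compound 2, is itself unreadable, so nothing points to a size or a direction for this assay. The limit shown for compound 2 in this assay is the only anchor. The step that the limit leaves unreadable from compound 2 to compound 3 is therefore expected to be none beyond the scatter. For compound 3 in this assay the estimate is 150000 nM, within 40000 nM to 600000 nM, and most likely the assay will again report only a limit.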

Compound 3, half-maximal inhibitory concentration: > 100000 nM
Compound 3: a limit, no number; the forecaster's own chance of this, stated with the estimate: 80%; the middle value lies beyond the limit too.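

Compound 3 also reaches only a limit in this assay, so neither the step from compound 2 to compound 3 nor the step from compound 1 to compound 3 can be read: the limit of > 100000 nM in this assay, at which 3 of the 3 values shown sit. The compounds shown leave open whether, in this assay, any group on the amide-type nitrogen gives a number rather than a limit.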